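A few compounds are considered here, and "the series" means these few. Any claim that something is new, unique, unknown or untested is made for them only; others in the source may bear on it.

Working notes on the series. Compound 1 `C=C1C(=O)[C@]23C[C@@]1(O)CC[C@H]2c1ccc(O)c(C)c1[C@@H]3Cn1cc(-c2ccc(Cl)cc2)nn1` and compound 2 `C=C1C(=O)[C@]23C[C@@]1(O)CC[C@H]2c1ccc(O)c(C)c1[C@@H]3Cn1cc(-c2ccc(C)cc2)nn1` share one core; compound 3 `C=C1C[C@]23C[C@@]1(O)CC[C@H]2c1cc(Br)c(O)c(C)c1[C@@H]3Cn1cc(-c2ccc(C)cc2)nn1` and compound 4 `C=C1C[C@]23C[C@@]1(O)CC[C@H]2c1cc(Br)c(O)c(C)c1[C@@H]3Cn1cc(-c2ccc(Cl)cc2)nn1` share a second core, and the difference between the two cores is not broken down here. In a functional assay on A549 cells (Homo sapiens) for cytotoxicity, read by MTT assay, with a stated time of 4 days (on this read-out higher numbers stand for weaker inhibition and lower numbers for stronger inhibition), compound 1 gives 640 nM. In this assay compound 2 gives 1260 nM. For compound 3 this assay reports only a limit, > 20000 nM; that limit is the one at the limit of > 20000 nM in this assay, at which 1 of the 3 values shown sits.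

The change from compound 2 to compound 1 is chloro in place of methyl on an aromatic carbon, and it made a 2.0-fold lower number from compound 2 to compound 1 (0.29 log units; within the scatter). Compound 4 carries the same change on the second core, (chloro in place of methyl on an aromatic carbon), with the same place on the ring. Since the measured step of this change stayed within the scatter, and since compound 3 sits at a limit, the expected step for compound 4 is a step that the limit leaves unreadable from compound 3 to compound 4, resting on a 2.0-fold lower number from compound 2 to compound 1 (0.29 log units; within the scatter) and on the limit of compound 3. Compound 4 is therefore estimated at 25000 nM, with the plausible range running from 8000 nM to 80000 nM, and a limit rather than a number is the more likely outcome.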

Compound 4, half-maximal inhibitory concentration: 10500 nM
Beside the measured number, compound 4's estimate is 2.4-fold (0.38 log units) above it; low and high end bracket the measured number.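

In this assay, the change from 4-methylphenyl to 4-chlorophenyl on the second core gives an at least 1.9-fold lower number from compound 3 to compound 4 (0.27 log units; that floor lies within the scatter), and the two cores can be set side by side: the same change on two cores in this assay, a 2.0-fold lower number (0.29 log units; within the scatter) from compound 2 to compound 1 and an at least 1.9-fold lower number (0.27 log units; that floor lies within the scatter) from compound 3 to compound 4; the limit leaves it open whether they differ

Compound 3 stands at a limit and not at a number, so the step on the second core is only a floor: the limit of > 20000 nM in this assay, at which 1 of the 4 values shown sits.

The pair fits a change that carries over from one core to the other, but it does not show that the step keeps its size, and neither step as printed lies beyond the scatter.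

Still open, on these data alone, is whether another group in the same place on the aromatic ring, such as methoxy, a nitrile or an amine, would move the number beyond the scatter on either core. Also open, as far as these compounds go, is what the difference between the two cores contributes, since they differ in more than one place and no comparison across them is drawn here.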